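The source may report more compounds than this note shows. Statements on the series, on what has been measured and on what is new or still open speak of the compounds shown alone.

Measured so far:
- Compound 1 `C/C=C1/[C@H](O[C@@H]2O[C@H](CO)[C@@H](O)[C@H](O)[C@H]2O)OC=C(C(=O)OC)[C@H]1CC(=O)OCCC`: in a functional assay on SK-BR-3 cells (Homo sapiens) for antiproliferative activity, read by MTT assay, with a stated time of 72 h (on this read-out lower numbers stand for stronger inhibition and higher numbers for weaker inhibition), compound 1 gives > 15000 nM, a limit of the assay.
- Compound 2 `C/C=C1/[C@H](O[C@@H]2O[C@H](CO)[C@@H](O)[C@H](O)[C@H]2O)OC=C(C(=O)OC)[C@H]1CC(=O)OCc1ccccc1`: in this assay compound 2 gives > 15000 nM, a limit of the assay.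
- Compound 3 `C/C=C1/[C@H](O[C@@H]2O[C@H](CO)[C@@H](O)[C@H](O)[C@H]2O)OC=C(C(=O)OC)[C@H]1CC(=O)OCCCC`: in this assay compound 3 gives > 15000 nM, a limit of the assay.

Among the measured compounds shown here, all three values sit at the same limit, (the limit of > 15000 nM in this assay, at which 3 of the 3 values shown sit), so no step among them can be read. The change from compound 1 to compound 2 is phenyl in place of ethyl on a saturated chain carbon bound to an oxygen next to a carbonyl group; its step is a step that the two limits leave unreadable from compound 1 to compound 2. The cores of compound 3 and compound 1 differ by methyl in place of hydrogen on a saturated chain carbon, three bonds along the chain from an oxygen next to a carbonyl group. Compound 4 `C/C=C1/[C@H](O[C@@H]2O[C@H](CO)[C@@H](O)[C@H](O)[C@H]2O)OC=C(C(=O)OC)[C@H]1CC(=O)OCCc1ccccc1` is not yet measured; it arises from compound 3 by phenyl in place of ethyl on a saturated chain carbon, two bonds along the chain from an oxygen next to a carbonyl group. This is the same kind of change as that from compound 1 to compound 2, but the place differs: there the phenyl sits on a saturated chain carbon bound to an oxygen next to a carbonyl group, here on a saturated chain carbon two bonds along the chain from an oxygen next to a carbonyl group. Because every value shown rests at the limit (the limit of > 15000 nM in this assay, at which 3 of the 3 values shown sit), the step expected from compound 3 to compound 4 is a step that the limit leaves unreadable from compound 3 to compound 4, estimated to stay unreadable. Compound 4 is expected at 20000 nM, estimated between 7000 nM and 60000 nM, most likely again reported as a limit.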

Compound 4, half-maximal inhibitory concentration: 11000 nM
Estimate against measurement, compound 4: 1.8-fold (0.26 log units) above; measured number inside the range.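

In this assay, the change of phenyl in place of ethyl, two bonds along the chain from an oxygen next to a carbonyl group, gives an at least 1.3-fold lower number from compound 3 to compound 4 (0.13 log units; that floor lies within the scatter). The comparisons with the other two esters give an at least 1.3-fold lower number from compound 2 to compound 4 (0.13 log units; that floor lies within the scatter) and an at least 1.3-fold lower number from compound 1 to compound 4 (0.13 log units; that floor lies within the scatter), so compound 4 carries a number, but no real separation from compounds 1, 2 and 3 is established. The steps among compounds 1, 2 and 3 cannot be read, so the same kind of change from compound 1 to compound 2 offers no size to set beside the step on compound 3, and carrying the change from one core to another is neither supported nor ruled out: the limit of > 15000 nM in this assay, at which 3 of the 4 values shown sit.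

Left open is how a longer chain, an amine or a carboxylic acid would read in place of the phenethyl group. Also open, on these data alone, is whether any ester on the shared core can give a number clearly separated from the limit in this assay.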